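The compounds below may be only part of what the source reports. "The series", "measured", "known", "first", "only" and "open" are said of these compounds alone.

Of the compounds shown here, two have been measured in a functional assay on MKN-45 cells (Homo sapiens) for cytotoxicity, read by MTT assay, with a stated time of 72 h; on this read-out higher numbers stand for weaker inhibition and lower numbers for stronger inhibition. Compound 1 `COc1ccc(-c2ccnc(C(=O)Nc3ccc(Oc4ccnc5cc(OCCCN6CCN(C)CC6)c(OC)cc45)c(F)c3)c2)c(OC)c1` gives 330 nM, and compound 2 `COc1cc2c(Oc3ccc(NC(=O)c4cc(-c5ccc(C(F)(F)F)cc5)ccn4)cc3F)ccnc2cc1OCCCN1CCCC1` gives 260 nM, the lowest of the two numbers, though the gap to compound 1 lies within the scatter. Compound 3 `COc1ccc(-c2ccnc(C(=O)Nc3ccc(Oc4ccnc5cc(OCCCN6CCCC6)c(OC)cc45)c(F)c3)c2)c(OC)c1` is not yet measured. It differs from compound 2 by 2,4-dimethoxyphenyl in place of 4-(trifluoromethyl)phenyl on an aromatic carbon. Compound 1 also carries the 2,4-dimethoxyphenyl group and gives 330 nM in this assay, so no step beyond the scatter is expected. Compound 3 is therefore estimated at 320 nM, with a range from 130 nM to 800 nM, a step of a 1.2-fold higher number from compound 2 to compound 3 (0.09 log units; within the scatter).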

Compound 3, half-maximal inhibitory concentration: 740 nM
The estimate for compound 3 lay 2.3-fold (0.36 log units) below the measured number; the measured number falls inside the stated range.
By their numbers in this assay, from the lowest: compounds 2 and 1 (each within the scatter of the next); then compound 3.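

With the pyrrolidin-1-yl chain held constant, replacing 4-(trifluoromethyl)phenyl with 2,4-dimethoxyphenyl opposite the ring nitrogen shifts the number in this assay beyond the scatter (a 2.8-fold higher number from compound 2 to compound 3 (0.45 log units; beyond the scatter)), so this position is not indifferent to the change. With 2,4-dimethoxyphenyl held constant, pyrrolidin-1-yl in place of 4-methylpiperazin-1-yl also gives a step beyond the scatter (a 2.2-fold higher number from compound 1 to compound 3 (0.35 log units; beyond the scatter)). No measurement at hand bears on the origin of either step. From the compounds shown here alone, whether the two changes would act in the same way with the other group in place remains open. So does the outcome with a morpholine on the chain or an unsubstituted phenyl on the aromatic carbon.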